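The source may report more compounds than this note shows. Statements on the series, on what has been measured and on what is new or still open speak of the compounds shown alone.

Values in a functional assay on HUVEC cells (Homo sapiens), read by scintillation counting and thymidine incorporation, with a stated time of 24 h; a lower number here means a stronger inhibitor, a higher number a weaker inhibitor:
- Compound 1 `CCC(C)n1ncn(-c2ccc(N3CCN(c4ccc(OC[C@@H]5CO[C@@](CC)(c6ccc(Cl)cc6Cl)O5)cc4)CC3)cc2)c1=O`: 353 nM
- Compound 2 `CCC(C)n1ncn(-c2ccc(N3CCN(c4ccc(OC[C@@H]5CO[C@@](CC6CCCC6)(c6ccc(Cl)cc6Cl)O5)cc4)CC3)cc2)c1=O`: 512 nM
- Compound 3 `CCC(C)n1ncn(-c2ccc(N3CCN(c4ccc(OC[C@@H]5CO[C@@](CN(C)C)(c6ccc(Cl)cc6Cl)O5)cc4)CC3)cc2)c1=O`: 1400 nM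

Compound 3 has the highest number of the three, with 1400 nM. Compound 4 `CCC(C)n1ncn(-c2ccc(N3CCN(c4ccc(OC[C@@H]5CO[C@@](CN6CCNCC6)(c6ccc(Cl)cc6Cl)O5)cc4)CC3)cc2)c1=O` has piperazin-1-yl in place of dimethylamino on a saturated chain carbon bound to a saturated ring carbon.

Three measured steps involve this place. Two are modest, a 4.0-fold higher number from compound 1 to compound 3 (0.60 log units; beyond the scatter) and a 2.7-fold higher number from compound 2 to compound 3 (0.44 log units; beyond the scatter), and one lies within the scatter, a 1.5-fold higher number from compound 1 to compound 2 (0.16 log units; within the scatter). Going by these compounds, none of them starts from dimethylamino and ends in another nitrogen group, so the direction remains open.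

In this assay, no shift beyond the scatter is expected, and the estimated change is a 1.2-fold lower number from compound 3 to compound 4 (0.07 log units; within the scatter). For compound 4 the expected value is 1200 nM, with an estimated range of 450 nM to 3000 nM.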

Compound 4, half-maximal inhibitory concentration: 608 nM
Beside the measured number, compound 4's estimate is 2.0-fold (0.30 log units) above it; the range from low to high includes it.
By their numbers in this assay, from the lowest: compounds 1, 2 and 4 (each within the scatter of the next); then compound 3.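

In this assay, a nitrogen group at this place on a saturated chain carbon need not give a higher number: piperazin-1-yl in place of dimethylamino gives a 2.3-fold lower number from compound 3 to compound 4 (0.36 log units; beyond the scatter). Against the carbon groups, piperazin-1-yl stays within the scatter, with a 1.2-fold higher number from compound 2 to compound 4 (0.07 log units; within the scatter) and a 1.7-fold higher number from compound 1 to compound 4 (0.24 log units; within the scatter). No measurement at hand accounts for the gap between the two nitrogen groups.

Going by these compounds, whether the ring or the ring amine hydrogen of piperazin-1-yl matters remains open. Morpholine or methylpiperazine at the same place would separate these two readings.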